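Amide aryl swap on the pyridine N-oxide piperidine acetamide series

The compounds below may be only part of what the source reports. "The series", "measured", "known", "first", "only" and "open" are said of these compounds alone.

Compound 1 `Cc1cc(NC(=O)CN2CCC(c3cccc[n+]3[O-])CC2)ccc1F` is the reference point of this set. Going by the values given here, in a functional assay on HEK293 cells for agonist activity at D(4) dopamine receptor (Homo sapiens), read by FLIPR (a lower number here means that less compound is needed, a higher number that more compound is needed for the effect), compound 1 gives 18 nM, the lowest number among the three measured members. Compound 2 `Cc1cccc(Cl)c1NC(=O)CN1CCC(c2ccccn2)CC1` gives 60 nM in this assay, a gap from compound 1 that lies beyond the scatter. Compound 3 `Cc1ccc(Cl)c(NC(=O)CN2CCC(c3cccc[n+]3[O-])CC2)c1Cl` gives 346 nM in this assay, the furthest of the three from compound 1 and clearly beyond the scatter. Compound 1 therefore holds the best position of the measured compounds, with compound 2 nearer and compound 3 distant.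

Compound 4 `O=C(CN1CCC(c2cccc[n+]2[O-])CC1)Nc1cccc(Cl)c1Cl` has not yet been measured. Relative to compound 1 the change is 2,3-dichlorophenyl in place of 4-fluoro-3-methylphenyl on an amide-type nitrogen. Among the compounds with values here, no measured pair in this set isolates this single change, so its size can only be judged from the spread of the three numbers, which shows that the aryl group on the amide nitrogen can move this assay by a meaningful amount.

For compound 4 a moderate rise in the number is expected, a step of a 2.8-fold higher number from compound 1 to compound 4 (0.44 log units; beyond the scatter) that is likely beyond the scatter but well short of the distance to compound 3. The estimate for compound 4 in this assay is 50 nM, with a range from 15 nM to 180 nM.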

Compound 4, half-maximal effective concentration: 180 nM
For compound 4 the middle estimate is 3.6-fold (0.56 log units) below the measured one; measured number inside the range.
By their numbers in this assay, from the lowest: compound 1; then compound 2; then compounds 4 and 3 (each within the scatter of the next).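

In this assay, going by these compounds alone, the swap of 4-fluoro-3-methylphenyl for 2,3-dichlorophenyl on the amide-type nitrogen gives a 10-fold higher number from compound 1 to compound 4 (1.00 log units; beyond the scatter), the first step in this set that isolates this position with the core held constant. It is beyond the scatter, even though the two groups match in their counts of heavy atoms, hydrogen-bond donors and hydrogen-bond acceptors, so those counts alone do not set the number here. Compound 4 at 180 nM and compound 3 at 346 nM lie within the scatter of each other, and no information is available on what lies behind the step.

The compounds shown do not separate the loss of the fluorine and methyl groups from the arrival of the two chlorines, and an unsubstituted phenyl or an aryl ring carrying a single nitrile or methoxy group would help to divide those contributions. On these data alone, the role of the N-oxide also stays open, since compound 2 differs from the others in more than one place and pairs with none of them.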